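The source may hold more compounds than are shown below. What is called first, only, known or untested is meant among the compounds shown, and "the series" means these compounds.

Measured so far in a functional assay on HCT-116 cells (Homo sapiens) for cytotoxicity, read by MTT assay, with a stated time of 48 h; a lower number here means a stronger inhibitor, a higher number a weaker inhibitor:
- compound 1, `C=CCOc1ccc2c(NCCCN(C)C)ccnc2c1`: 2100 nM
- compound 2, `CCOc1ccc2c(NCCCN(C)C)ccnc2c1`: 3380 nM

Compound 2 gives the highest of the two numbers in this assay, and its nearest neighbour is compound 1, separated only by a 1.6-fold higher number from compound 1 to compound 2 (0.21 log units; within the scatter). Both numbers therefore sit together and neither compound can be called the stronger one.

Compound 3, `CN(C)CCCNc1ccnc2cc(OCc3ccc(F)cc3)ccc12`, differs from compound 2 by 4-fluorophenyl in place of methyl on a saturated chain carbon bound to an oxygen on an aromatic ring. For the measured compounds named here, the only measured step that touches the same place is the one from compound 1 to compound 2, and that step is a 1.6-fold higher number from compound 1 to compound 2 (0.21 log units; within the scatter). Going by the values given here, it swaps two small groups and says nothing about a six-membered aromatic ring of carbon only entering at this position; no measured pair covers such a change. With so little to go on, the expected step in this assay from compound 2 to compound 3 is a 1.4-fold lower number from compound 2 to compound 3 (0.13 log units; within the scatter), in no particular direction, and with a wide range.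

For compound 3 the estimate in this assay is 2500 nM, with a range from 700 nM to 9000 nM.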

Compound 3, half-maximal inhibitory concentration in the HCT-116 assay: 740 nM
Estimate against measurement, compound 3: 3.4-fold (0.53 log units) above; the range from low to high includes it.
By their numbers in the HCT-116 assay, from the lowest: compound 3; then compounds 1 and 2 (each within the scatter of the next).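

In the HCT-116 assay, the saturated chain carbon bound to an oxygen on an aromatic ring now gives steps beyond the scatter, which the swap of methyl for vinyl did not: a 4.6-fold lower number from compound 2 to compound 3 (0.66 log units; beyond the scatter) and a 2.8-fold lower number from compound 1 to compound 3 (0.45 log units; beyond the scatter), both with 4-fluorophenyl entering and bringing a six-membered aromatic ring of carbon only to this place. In a physicochemical assay for solubility (on this read-out lower numbers stand for lower solubility and higher numbers for higher solubility), compound 2 gives > 10000 ug/mL, which is a limit of the assay and not a number. In the physicochemical assay compound 3 gives > 10000 ug/mL, again a limit, and the step from methyl to 4-fluorophenyl cannot be read on this read-out.

Open, going by these compounds, is how much of the change in the cytotoxicity read-out belongs to the ring and how much to its fluorine, which an unsubstituted phenyl in the same place would separate. Also open, on these data alone, is whether a saturated ring such as cyclohexyl would give a step of similar size.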